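The source may hold more compounds than are shown below. What is called first, only, known or untested is meant among the compounds shown, and "the series" means these compounds.

Working notes on a small set of nucleoside analogues sharing one core and differing only in the substituent attached to it, all run in an assay on isolated protein for binding affinity to Equilibrative nucleoside transporter 1 (Homo sapiens); a higher number here means a weaker inhibitor, a lower number a stronger inhibitor.

Compound 1 `CCCCCNc1ncnc2c1ncn2[C@@H]1O[C@H](CO)[C@@H](O)[C@H]1O` gives 13500 nM in this assay. Compound 2 `OC[C@H]1O[C@@H](n2cnc3c(SCC4CCCCC4)ncnc32)[C@H](O)[C@@H]1O` gives 1550 nM, the step being an 8.7-fold lower number from compound 1 to compound 2 (0.94 log units; beyond the scatter). Compound 3 `OC[C@H]1O[C@@H](n2cnc3c(SCCCc4ccccc4)ncnc32)[C@H](O)[C@@H]1O` gives 1350 nM, the lowest of the three numbers, although the step of a 1.1-fold lower number from compound 2 to compound 3 (0.06 log units; within the scatter) remains within scatter, so only compound 1 stands clearly apart from it.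

The next entry, compound 4 `Cc1ccc(CSc2ncnc3c2ncn3[C@@H]2O[C@H](CO)[C@@H](O)[C@H]2O)cc1`, carries 4-methylphenyl in place of phenethyl on a saturated chain carbon bound to a sulfur. For the measured compounds named here, the only measured step at that place, a 1.1-fold lower number from compound 2 to compound 3 (0.06 log units; within the scatter), was flat; the step of an 8.7-fold lower number from compound 1 to compound 2 (0.94 log units; beyond the scatter) concerns a different place and bears less directly. Compound 4 is therefore expected to move little, a 1.1-fold higher number from compound 3 to compound 4 (0.05 log units; within the scatter), with an estimated value of 1500 nM and a range from 600 nM to 4000 nM.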

Compound 4, half-maximal inhibitory concentration: 457 nM
For compound 4 the middle estimate is 3.3-fold (0.52 log units) above the measured one; the whole stated range lies above it.
By their numbers in this assay, from the lowest: compound 4; then compounds 3 and 2 (each within the scatter of the next); then compound 1.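

At the saturated chain carbon bound to a sulfur, a place that looked flat so far now responds: 3-phenylpropyl to 4-methylbenzyl gives (a 3.0-fold lower number from compound 3 to compound 4 (0.47 log units; beyond the scatter)), and cyclohexyl to 4-methylphenyl gives (a 3.4-fold lower number from compound 2 to compound 4 (0.53 log units; beyond the scatter)). The full change from pentylamino to (4-methylbenzyl)sulfanyl on the aromatic carbon gives (a 30-fold lower number from compound 1 to compound 4 (1.47 log units; beyond the scatter)). No supporting data explain these steps in this assay.

Open, from the compounds shown here alone, is whether the step follows the methyl group or the shorter chain, as both change together; a plain benzyl group would separate them. Also open, going by these compounds, is how a 4-methylbenzylamino group would compare with the sulfur-linked one.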